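The compounds below may be only part of what the source reports. "The series", "measured", "known", "first", "only" and "open" are said of these compounds alone.

Measured so far in a functional assay on HEp-2 cells (Homo sapiens) for cytotoxicity, read by sulforhodamine B assay, with a stated time of 48 h; on this read-out lower numbers stand for stronger inhibition and higher numbers for weaker inhibition:
compound 1 `COc1ccc(C2CC(c3cccc4ccccc34)=NN2C(C)=O)cc1OC` gives 1030 nM
compound 2 `COc1cc(C2CC(c3cccc4ccccc34)=NN2C(C)=O)ccc1O` gives 1130 nM
compound 3 `COc1ccc(C2CC(c3ccc4ccccc4c3)=NN2CC=O)cc1OC` gives 1010 nM

Compound 4 `COc1ccc(C2CC(c3ccc4ccccc4c3)=NN2CC=O)cc1O` is not yet measured. Compound 1 and compound 2 share one core; the change between them is hydrogen in place of methyl on an oxygen on an aromatic ring, and on measurement it gave a 1.1-fold higher number from compound 1 to compound 2 (0.04 log units; within the scatter). Compound 3 is built from the same atoms as compound 1, joined differently; the difference between the two cores is not broken down here. Compound 4 differs from compound 3 by hydrogen in place of methyl on an oxygen on an aromatic ring, which is the same change as that from compound 1 to compound 2, made at a place described in the same words. The three measured values all lie within the usual scatter of one another, so no ordering among them is claimed.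

For compound 4 the step in this assay is expected to be small, about a 1.1-fold higher number from compound 3 to compound 4 (0.04 log units; within the scatter), because the earlier instance of this change gave a 1.1-fold higher number from compound 1 to compound 2 (0.04 log units; within the scatter). Compound 4 is therefore estimated at 1100 nM. The expected range for compound 4 runs from 600 nM to 2000 nM.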

Compound 4, half-maximal inhibitory concentration: 1020 nM
The estimate for compound 4 lay 1.1-fold (0.03 log units) above the measured number; the range from low to high includes it.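

In this assay, the change from methoxy to hydroxy gives a 1.0-fold higher number from compound 3 to compound 4 (0.00 log units; within the scatter). Set beside the earlier instance, the step carries from one core to the other without a difference that can be told apart: the same change on two cores in this assay, a 1.1-fold higher number (0.04 log units; within the scatter) from compound 1 to compound 2 and a 1.0-fold higher number (0.00 log units; within the scatter) from compound 3 to compound 4, 1.1-fold (0.04 log units) apart, within the scatter of two such steps

This shows that, on these two cores, replacing the methyl on this oxygen with hydrogen leaves the number within the scatter, but it rests on only two instances and does not show that the step would stay this small on any other core of the series.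

The compounds shown leave open what a larger change at this oxygen would do in this assay, for example a longer chain such as propoxy, or an amine or a carboxylic acid in place of the hydroxy. They also leave open whether methoxy to hydroxy stays this small in any read-out other than this assay.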